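Pyrrolidin-1-yl in Place of Hydroxy on a Carbonyl Carbon

The source may hold more compounds than are shown below. What is called first, only, known or untested is meant among the compounds shown, and "the series" means these compounds.

Measured compounds:
compound 1, `CC(C)=CCC[C@]1(C)/C=C/[C@@H](OC(=O)C=C(C)C)[C@](C)(O)/C=C/C(=O)/C(C(=O)O)=C\C1` — > 10000 nM
compound 2, `CC(C)=CCC[C@]1(C)/C=C/[C@@H](OC(=O)C=C(C)C)[C@](C)(O)CCC(=O)/C(CO)=C\C1` — > 40000 nM

In a functional assay on HL-60 cells (Homo sapiens) for antiproliferative activity, read by MTT assay, with a stated time of 48 h (on this read-out lower numbers stand for stronger inhibition and higher numbers for weaker inhibition), compound 1 gives > 10000 nM, which is a limit of the assay rather than a number. Compound 2 gives > 40000 nM, which is likewise a limit. Within the data shown here, compound 1 therefore stands at a limit, and the other value shown is also one, so no sized step between measured compounds can be read from these two values.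

Compound 3, `CC(C)=CCC[C@]1(C)/C=C/[C@@H](OC(=O)C=C(C)C)[C@](C)(O)/C=C/C(=O)/C(C(=O)N2CCCC2)=C\C1`, has not yet been measured. It differs from compound 1 in one place: pyrrolidin-1-yl in place of hydroxy on a carbonyl carbon. Among the measured compounds shown here, no step between two measured compounds points the way here, so the expected size of the step rests on the change alone. A modest move toward stronger inhibition seems plausible, but a result that again sits at a limit cannot be ruled out. Compound 3 is estimated to give 5000 nM, with a range from 800 nM to 30000 nM. This estimate means an expected step of an at least 2.0-fold lower number from compound 1 to compound 3 (0.30 log units; that floor lies within the scatter).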

Compound 3, half-maximal inhibitory concentration: 12300 nM
Estimate against measurement, compound 3: 2.5-fold (0.39 log units) below; the measured number falls inside the stated range.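

No step from compound 1 to compound 3 can be read, because the value of compound 1 is a limit and not a number: the limit of > 10000 nM in this assay, at which 1 of the 3 values shown sits.

The compounds shown leave open whether pyrrolidin-1-yl in place of hydroxy on a carbonyl carbon strengthens or weakens inhibition, and by how much.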